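Removing a methyl from an aromatic oxygen in myeloperoxidase inhibitors

The source may report more compounds than this note shows. Statements on the series, on what has been measured and on what is new or still open speak of the compounds shown alone.

Four compounds sharing a propylamine linker between two aromatic rings are considered here. Compound 1 `COc1ccccc1CCCNCc1ccccc1O` carries a methoxy on one ring and a hydroxy on the other, and in an assay on isolated protein for inhibition of Myeloperoxidase (Homo sapiens), with a stated time of 5 min, in the presence of a further agent that is not named here (a higher number here means a weaker inhibitor, a lower number a stronger inhibitor), compound 1 gives 2500 nM. Compound 2 `Oc1ccccc1CCCNCc1ccccc1O` differs from it by hydrogen in place of methyl on an oxygen on an aromatic ring, and in this assay compound 2 gives 350 nM, so that the step of a 7.1-fold lower number from compound 1 to compound 2 (0.85 log units; beyond the scatter) is a clear gain in potency.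

Compound 3 `COc1ccccc1CCCNCc1ccc(F)cc1` shares the methoxy-bearing ring of compound 1 but differs from it elsewhere; the difference between the two cores is not broken down here, and in this assay compound 3 gives no result reported. Compound 4 `Oc1ccccc1CCCNCc1ccc(F)cc1` stands to compound 3 as compound 2 stands to compound 1, through (hydrogen in place of methyl on an oxygen on an aromatic ring), the same change at the same place.

Without a measured anchor in compound 3, the expectation for compound 4 rests on compound 2, whose value 350 nM shows what the hydroxy-bearing core achieves, and on the size of the gain seen in a 7.1-fold lower number from compound 1 to compound 2 (0.85 log units; beyond the scatter). Compound 4 is accordingly estimated at 800 nM, within an expected range from 150 nM to 5000 nM.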

Compound 4, half-maximal inhibitory concentration: 490 nM
For compound 4 the middle estimate is 1.6-fold (0.21 log units) above the measured one; the measured number falls inside the stated range.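

Compound 3 has no single number in this assay, so the step to compound 4, which gives 490 nM, cannot be read. The compounds shown leave open whether methoxy to hydroxy on the core of compound 3 brings a change of the size of a 7.1-fold lower number from compound 1 to compound 2 (0.85 log units; beyond the scatter). Nothing shown offers an explanation for the value of compound 4.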